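A few compounds are considered here, and "the series" means these few. Any claim that something is new, unique, unknown or untested is made for them only; others in the source may bear on it.

Compound 1, with the structure `Cc1ccncc1-c1ccc2[nH]c(=O)nc(-c3ccccc3)c2c1`, is one of two quinazolinone-free aryl compounds examined here; call it simply the shared core bearing a 4-methylpyridin-3-yl group. In an ADME assay on L6 cells (Rattus norvegicus) for cytotoxicity, read by fluorescence and resazurin assay, with a stated time of 72 h (a lower number here means that less compound is needed, a higher number that more compound is needed for the effect), compound 1 gives > 50000 nM, which is a limit of the assay rather than a number. Compound 2, with the structure `O=c1nc(-c2ccccc2)c2cc(-c3ccc(N4CCCC4)nc3)ccc2[nH]1`, carries a pyrrolidinyl-substituted pyridine on the same core. In this assay compound 2 gives > 50000 nM, again a limit of the assay rather than a number. Both values therefore sit at the same point, as the limit of > 50000 nM in this assay, at which 2 of the 2 values shown sit, records, so compound 1 cannot be placed above or below compound 2 on the numbers shown.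

Compound 3, with the structure `Cc1ccc2[nH]c(=O)nc(-c3ccccc3)c2c1`, is not yet measured. It differs from compound 1 as follows: methyl in place of 4-methylpyridin-3-yl on an aromatic carbon. Given that compound 1 shows only a limit in this assay, the step that the limit leaves unreadable from compound 1 to compound 3 is expected to stay within the scatter, with no change in direction that the data could support. Compound 3 is thus expected to give about 60000 nM, within the range 25000 nM to 150000 nM, most likely reported again only as a limit.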

Compound 3, half-maximal effective concentration: > 50000 nM
Compound 3 gave a limit, no number (the forecaster's own chance of this, stated with the estimate: 80%); the middle value is on the limit's open side.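

Compound 1 and compound 3 both give only a limit in this assay, and no step between them can be read: the limit of > 50000 nM in this assay, at which 3 of the 3 values shown sit.

The compounds shown leave open where any of them would give an actual number in this assay, and whether any group on the shared core would bring a measurable value.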